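Chain lengthening from compound 3 to compound 4

A few compounds are considered here, and "the series" means these few. Any claim that something is new, unique, unknown or untested is made for them only; others in the source may bear on it.

Measured in a functional assay on Bel-7402 cells (Homo sapiens) for inhibition, read by MTT assay, with a stated time of 72 h; a lower number here means a stronger inhibitor, a higher number a weaker inhibitor:
- compound 1 `CNC(=O)CCCCCCCn1nc(-c2cnc3[nH]ccc3c2)c2c(N)ncnc21`: 17400 nM
- compound 2 `Nc1ncnc2c1c(-c1cnc3[nH]ccc3c1)nn2CCCCCC(=O)NO`: "not determined" (no result reported)
- compound 3 `Nc1nc2cc(-c3nn(CCCCC(=O)NO)c4ncnc(N)c34)ccc2o1`: 2400 nM

Compound 3 holds the lower of the two numbers at 2400 nM, and compound 1 stands at 17400 nM, a gap beyond the scatter. Compound 4 `Nc1nc2cc(-c3nn(CCCCCCC(=O)NO)c4ncnc(N)c34)ccc2o1` is still unmeasured. It carries 2-(hydroxycarbamoyl)ethyl in place of hydroxycarbamoyl on a saturated chain carbon, four bonds along the chain from an aromatic nitrogen. Among the measured compounds shown here, no measured pair isolates this change, so the expectation is anchored only on compound 3 at 2400 nM. The expected step is a 2.4-fold lower number from compound 3 to compound 4 (0.38 log units; beyond the scatter) in this assay, a modest move toward a lower number, slightly beyond the scatter. For compound 4 the estimate is 1000 nM, with an expected range from 250 nM to 4000 nM.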

Compound 4, half-maximal inhibitory concentration: > 50000 nM
Compound 4: no number, only a limit (the forecaster's own chance of this, stated with the estimate: 5%); middle value at least 50-fold (1.69 log units) away from the limit.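

In this assay, 2-(hydroxycarbamoyl)ethyl in place of hydroxycarbamoyl at this saturated chain carbon gives an at least 20-fold higher number from compound 3 to compound 4 (1.31 log units; beyond the scatter), a large step. Chain length at this place therefore weighs heavily in this assay, which the earlier compounds, differing in more than one place, could not show. Going by these compounds, compound 4 carries a limit and not a number, so the full size of the step stays unknown: the limit of > 50000 nM in this assay, at which 1 of the 4 values shown sits.

Still open is where along the chain the loss sets in, as no chain of intermediate length is shown. Also open, on these data alone, is whether a carboxylic acid in place of hydroxycarbamoyl would keep the number of compound 3.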